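Hydroxybutyl amide series: losing one methyl from compound 3

A few compounds are considered here, and "the series" means these few. Any claim that something is new, unique, unknown or untested is made for them only; others in the source may bear on it.

Measured in an in vitro ADME assay on microsomes from Gut (Homo sapiens) for metabolic stability, in the presence of a further agent that is not named here; a lower number here means slower removal, a higher number faster removal of the compound:
- compound 1 `CC(C)(CO)CNC(=O)c1cc2cc(C#N)ccc2n1Cc1cccc(OC(F)(F)F)c1`: 136 mL.min-1.g-1
- compound 2 `COc1ccc(Cl)cc1Cn1c(C(=O)NCC(C)(C)CO)cc2cc(C#N)ccc21`: 63 mL.min-1.g-1
- compound 3 `CC(C)(O)CCNC(=O)c1cc2cc(C#N)ccc2n1Cc1cccc(OC(F)(F)F)c1`: 9 mL.min-1.g-1

Compound 3 has the lowest number of the three, and both compound 2 and compound 1 lie above it beyond the scatter, with compound 1 furthest away. The next compound is compound 4 `CC(O)CCNC(=O)c1cc2cc(C#N)ccc2n1Cc1cccc(OC(F)(F)F)c1`, which differs from compound 3 as follows: hydrogen in place of methyl on a saturated chain carbon bound to an oxygen on a saturated carbon and two saturated chain carbons. In terms of the chain, this is 3-hydroxy-3-methylbutyl to 3-hydroxybutyl.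

Among the compounds with values here, only one measured step touches this chain: a 15-fold lower number from compound 1 to compound 3 (1.18 log units; beyond the scatter), a large step with 2-hydroxy-2-methylpropyl in place of 1-(hydroxymethyl)-1-methylethyl on a saturated chain carbon bound to an amide-type nitrogen. It shows that a change in this chain can move the number well beyond the scatter, but it is a different change. Within the data shown here, no measured pair shows the loss of this methyl, so its size can only be judged loosely. With compound 3 at 9 mL.min-1.g-1, the lowest of the three numbers, a modest upward move in this assay is expected rather than a step as large as the measured one. The expected step is a 1.8-fold higher number from compound 3 to compound 4 (0.25 log units; within the scatter). For compound 4 the estimated value is 16 mL.min-1.g-1, with an expected range of 6 mL.min-1.g-1 to 45 mL.min-1.g-1.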

Compound 4, intrinsic clearance in microsomes: < 6 mL.min-1.g-1
Compound 4: a limit, no number; the forecaster's own chance of this, stated with the estimate: 10%; middle value at least 2.6-fold (0.42 log units) away from the limit.
By their numbers in this assay, from the lowest: compound 3; then compound 2; then compound 1. At a limit, below all of these: compound 4.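

Compound 4 gives a limit and not a number in this assay: the limit of < 6 mL.min-1.g-1 in this assay, at which 1 of the 4 values shown sits.

Within the data shown here, no earlier pair isolated this methyl, and the change from 3-hydroxy-3-methylbutyl to 3-hydroxybutyl now gives an at least 1.5-fold lower number from compound 3 to compound 4 (0.17 log units; that floor lies within the scatter); that floor lies within the scatter, so this pair alone does not establish a real fall, but it does show that the methyl on this saturated chain carbon is not required for a low number in this assay. Against the chain of compound 1, the 2-hydroxypropyl form gives an at least 22-fold lower number from compound 1 to compound 4 (1.35 log units; beyond the scatter), so the large difference first seen with compound 3 persists once the methyl is gone.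

Still open, on these data alone, is whether the hydroxyl on this chain matters at all, which a plain butyl chain, a 3-methoxybutyl chain or a 3-aminobutyl chain on the shared core would address. The limit also leaves the true size of the methyl step unresolved, and the compounds shown do not tell whether the same change would act alike on the core of compound 2.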